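Swapping phenyl for thiophene on a flavone sigma ligand

This account rests on a few compounds, and the source may have more. Where it says the series, first, only, none or still open, it means among the compounds named here.

Compound 1 `CN(C)CCCCCCCCCCOc1ccc2oc(-c3ccccc3)cc(=O)c2c1` gives 341 nM in an assay on isolated protein (Cavia porcellus) with Sigma non-opioid intracellular receptor 1 (Homo sapiens) as the target, read by radioligand binding; on this read-out higher numbers stand for weaker inhibition and lower numbers for stronger inhibition. Within the data shown here, compound 2 `O=c1cc(-c2ccccc2)oc2ccc(OCCCCCCN3CCC(O)CC3)cc12` gives 121 nM, and the single step recorded so far, a 2.8-fold lower number from compound 1 to compound 2 (0.45 log units; beyond the scatter), concerns only the chain end; compound 2 therefore holds the lowest number of the two. Compound 3 `O=c1cc(-c2cccs2)oc2ccc(OCCCCCCN3CCC(O)CC3)cc12` differs from compound 2 by thiophen-2-yl in place of phenyl on an aromatic carbon. Among the measured compounds shown here, no measured step touches this position, so nothing here bears on it directly, and the expected step of a 1.1-fold lower number from compound 2 to compound 3 (0.04 log units; within the scatter) is judged to lie within the usual scatter. Compound 3 is estimated at 110 nM, with a range from 40 nM to 300 nM.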

Compound 3, half-maximal inhibitory concentration: 232 nM
Beside the measured number, compound 3's estimate is 2.1-fold (0.32 log units) below it; low and high end bracket the measured number.
By their numbers in this assay, from the lowest: compounds 2, 3 and 1 (each within the scatter of the next, the first and the last beyond it).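

Among these compounds, compound 3 gives the first reading at this position, the aromatic carbon next to the ring oxygen, which the earlier step at the chain end did not touch. In this assay, thiophen-2-yl in place of phenyl gives a 1.9-fold higher number from compound 2 to compound 3 (0.28 log units; within the scatter), so this read-out does not tell the two rings apart. No measured information explains this result.

Still open, on these data alone, is whether cyclohexyl or a pyridine ring at this position would fit as well as these two rings. As far as these compounds go, whether thiophen-2-yl behaves the same with the dimethylamino chain end of compound 1 also remains unknown.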